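Extending the thioether chain from methyl toward ethyl

The compounds below may be only part of what the source reports. "The series", "measured", "known", "first", "only" and "open" are said of these compounds alone.

Of the compounds shown here, three sharing one core have been tested in a functional assay on the whole organism for inhibition, with Mus musculus as the target; on this read-out lower numbers stand for an effect already at smaller amounts and higher numbers for an effect only at larger amounts of compound. Compound 1 `CCCCSc1nsnc1C1CN2CCC[C@H]1C2` gives 0.045 mg/kg in this assay. Compound 2 `CCCCSc1nsnc1[C@@H]1CN2CCC[C@H]1C2` gives 0.026 mg/kg, and the two differ only in that (the fact that one of compounds 1 and 2 is drawn with a defined configuration and the other without, at the place where they differ); the step of a 1.7-fold lower number from compound 1 to compound 2 (0.24 log units; within the scatter). Compound 3 `CSc1nsnc1C1CN2CCC[C@H]1C2` gives 0.2 mg/kg, the highest number of the three, with compound 1 the nearest and compound 2 the furthest. The change from compound 1 to compound 3 is hydrogen in place of propyl on a saturated chain carbon bound to a sulfur, and the step is a 4.4-fold higher number from compound 1 to compound 3 (0.65 log units; beyond the scatter).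

Compound 4 `CCSc1nsnc1C1CN2CCC[C@H]1C2` is not yet measured. It differs from compound 3 by methyl in place of hydrogen on a saturated chain carbon bound to a sulfur. Going by the values given here, the only measured step that bears on the chain at this place is a 4.4-fold higher number from compound 1 to compound 3 (0.65 log units; beyond the scatter), which shows that three carbons removed from the chain raise the number modestly. One carbon added back is expected to recover part of that, and compound 4 is therefore expected to give a somewhat lower number than compound 3 in this assay, the expected step being a 2.0-fold lower number from compound 3 to compound 4 (0.30 log units; within the scatter). The estimate for compound 4 is 0.1 mg/kg, with a range from 0.04 mg/kg to 0.25 mg/kg.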

Compound 4, dose for half-maximal effect: 0.047 mg/kg
For compound 4 the middle estimate is 2.1-fold (0.33 log units) above the measured one, within the range that was stated.
By their numbers in this assay, from the lowest: compounds 2, 1 and 4 (each within the scatter of the next); then compound 3.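

Compound 4 shows that the single methyl entering on a saturated chain carbon bound to a sulfur, which turns methylsulfanyl into ethylsulfanyl, is enough to move the number in this assay by a step beyond the scatter (a 4.3-fold lower number from compound 3 to compound 4 (0.63 log units; beyond the scatter)). The earlier compounds showed only that the long chain and the methylsulfanyl group differ, whereas the ethylsulfanyl group now cannot be told apart from the longer chain (a 1.0-fold higher number from compound 1 to compound 4 (0.02 log units; within the scatter)), so among these compounds the whole difference is already present with ethyl, and further length adds nothing that can be read. Nothing in the information available bears on why this one added methyl has so large a step in the whole-organism read-out.

Going by these compounds alone, what a propyl chain, a chain longer than the one in compound 1, or a chain ending in an amine or a carboxylic acid would give remains open. Also open, on these data alone, is whether a defined configuration at the ring carbon, as drawn in compound 2, would alter the step seen for the ethylsulfanyl group.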